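Aryl Sulfonamide Variation on a Shared Core: Toward Compound 3

The source may hold more compounds than are shown below. What is called first, only, known or untested is meant among the compounds shown, and "the series" means these compounds.

Compound 1, `COc1ccc(OC)c(S(=O)(=O)NC2=NCCN2C(=S)SN2CCn3c2nsc3=S)c1`: >= 20000 nM
Compound 2, `CC(=O)Nc1ccc(S(=O)(=O)NC2=NCCN2C(=S)SN2CCn3c2nsc3=S)cc1`: >= 20000 nM

In a functional assay on KYSE-510 cells (Homo sapiens) for antiproliferative activity, read by crystal violet staining, with a stated time of 96 h (on this read-out higher numbers stand for weaker inhibition of growth and lower numbers for stronger inhibition of growth), compound 1 gives >= 20000 nM, which is a limit of the assay rather than a number. In this assay compound 2 gives >= 20000 nM, also a limit. Both measured values thus sit at the limit of >= 20000 nM in this assay, at which 2 of the 2 values shown sit, and the step that the two limits leave unreadable from compound 1 to compound 2 cannot be read. Compound 2 therefore stands at the limit, with no numeric value on record.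

Compound 3, `O=S(=O)(NC1=NCCN1C(=S)SN1CCn2c1nsc2=S)c1ccc2ccccc2c1`, differs from compound 2 by naphthalen-2-yl in place of 4-acetamidophenyl on a sulfonyl sulfur. Among the measured compounds shown here, no measured step bears on this change, and the only measured step is unreadable, so there is no basis for expecting a step beyond the scatter in either direction. Compound 3 is expected to remain near the limit, with an estimated value of 30000 nM and a range from 10000 nM to 100000 nM. The step that the limit leaves unreadable from compound 2 to compound 3 is expected to show no clear direction.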

Compound 3, concentration for 50% growth inhibition: >= 20000 nM
Compound 3 gave a limit, no number; the forecaster's own chance of this, stated with the estimate: 80%; the middle value is on the limit's open side.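

In this assay compound 3 gives >= 20000 nM, which is a limit of the assay. No step from compound 1 or compound 2 to compound 3 can be read: the limit of >= 20000 nM in this assay, at which 3 of the 3 values shown sit.

The compounds shown leave open how naphthalen-2-yl, 4-acetamidophenyl and 2,5-dimethoxyphenyl on the sulfonyl sulfur rank against one another.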